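Replacing an Alkene Chain with a 2-Bromobenzyl Ether

A few compounds are considered here, and "the series" means these few. Any claim that something is new, unique, unknown or untested is made for them only; others in the source may bear on it.

Compound 1 `COc1cc(OC)c(-c2coc3cc(OCC=C(C)C)ccc3c2=O)cc1OC` has been tested in a functional assay on A-375 cells (Homo sapiens) for antiproliferative activity, read by MTT assay, with a stated time of 24 h (on this read-out lower numbers stand for stronger inhibition and higher numbers for weaker inhibition), where compound 1 gives 1580 nM. Among the three measured compounds it holds the second highest number. Compound 2 `C#CCOc1ccc2c(=O)c(-c3cc(OC)c(OC)cc3OC)coc2c1` gives 3680 nM, and compound 3 `COc1cc(OC)c(-c2coc3cc(OCc4ccccc4C#N)ccc3c2=O)cc1OC` gives 990 nM. In steps, a 2.3-fold higher number from compound 1 to compound 2 (0.37 log units; beyond the scatter), whereas a 1.6-fold lower number from compound 1 to compound 3 (0.20 log units; within the scatter), and a 3.7-fold lower number from compound 2 to compound 3 (0.57 log units; beyond the scatter).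

Compound 4 `COc1cc(OC)c(-c2coc3cc(OCc4ccccc4Br)ccc3c2=O)cc1OC` differs from compound 1 in one place: 2-bromophenyl in place of 2-methylprop-1-en-1-yl on a saturated chain carbon bound to an oxygen on an aromatic ring. The comparison that bears most directly on this change is compound 3, where a 2-cyanophenyl entered at the same place and the number stayed within the scatter of compound 1. The step to compound 2, where a much smaller ethynyl entered, went the other way but is a different kind of change. With one aromatic ring at this place leaving the number essentially where it was, a 2-bromophenyl there is expected to behave alike, so the estimated step is a 1.4-fold lower number from compound 1 to compound 4 (0.16 log units; within the scatter), nothing beyond the scatter. Compound 4 is therefore expected to give about 1100 nM, with a range from 450 nM to 2700 nM.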

Compound 4, half-maximal inhibitory concentration: 2850 nM
Compound 4: the middle estimate sits 2.6-fold (0.41 log units) below what was measured; measured number outside the range, above it.
By their numbers in this assay, from the lowest: compounds 3, 1, 4 and 2 (each within the scatter of the next, the first and the last beyond it).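

In this assay, the aromatic ring at this place does not settle the number by itself, as exchanging the nitrile for bromo gives a 2.9-fold higher number from compound 3 to compound 4 (0.46 log units; beyond the scatter). So the group carried on that ring matters here, which compound 3 alone could not show. Yet compound 4 stays within the scatter on both other steps, a 1.8-fold higher number from compound 1 to compound 4 (0.26 log units; within the scatter) and a 1.3-fold lower number from compound 2 to compound 4 (0.11 log units; within the scatter), so it cannot be ranked against compound 1 or compound 2, and no data shown explain the difference between bromo and nitrile.

The compounds shown leave open how a plain benzyl group, or a benzyl carrying an amine or a carboxylic acid, would read at this place. They also leave open whether a longer chain ending in an aromatic ring would behave like 2-bromobenzyl.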